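The compounds below may be only part of what the source reports. "The series", "measured", "known", "first", "only" and "open" are said of these compounds alone.

Compound 1 `COc1cc2cc(Oc3ccc(NC(=O)Nc4cccc(C(F)(F)F)c4)cc3)c(C)nc2cc1OC`: 1840 nM in a functional assay on UACC-62 cells (Homo sapiens) for inhibition, read by sulforhodamine B assay, with a stated time of 48 h; on this read-out lower numbers stand for stronger inhibition of growth and higher numbers for weaker inhibition of growth.
Compound 2 `COc1cc2cc(Oc3ccc(NC(=O)Nc4ccc(Cl)c(C(F)(F)F)c4)cc3)c(C)nc2cc1OC`: 1240 nM in this assay.

Compound 2 and compound 1 sit within the scatter of one another, as the step of a 1.5-fold lower number from compound 1 to compound 2 (0.17 log units; within the scatter) shows. Compound 3 `COc1cc2cc(Oc3ccc(NC(=O)Nc4ccc(Cl)c(Cl)c4)cc3)c(C)nc2cc1OC` differs from compound 2 by chloro in place of trifluoromethyl on an aromatic carbon. Going by the values given here, no measured step swaps these two groups; the only measured step, a 1.5-fold lower number from compound 1 to compound 2 (0.17 log units; within the scatter), concerns a different change on the same ring and points to no direction. The step in this assay is therefore expected to stay small, a 1.2-fold higher number from compound 2 to compound 3 (0.08 log units; within the scatter). Compound 3 is estimated at 1500 nM, between 600 nM and 3800 nM.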

Compound 3, concentration for 50% growth inhibition: 3330 nM
For compound 3 the middle estimate is 2.2-fold (0.35 log units) below the measured one; the range from low to high includes it.
By their numbers in this assay, from the lowest: compounds 2, 1 and 3 (each within the scatter of the next, the first and the last beyond it).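

In this assay, trifluoromethyl and chloro are not interchangeable at this position, ortho to a chloro group: the change gives a 2.7-fold higher number from compound 2 to compound 3 (0.43 log units; beyond the scatter), a modest step beyond the scatter and toward weaker inhibition of growth. Replacing 3-(trifluoromethyl)phenyl with 3,4-dichlorophenyl gives a 1.8-fold higher number from compound 1 to compound 3 (0.26 log units; within the scatter), which stays within the scatter. Nothing measured here explains the difference between trifluoromethyl and chloro.

Going by these compounds, it remains open how a methoxy, a nitrile or a tert-butyl group would behave at this position. On these data alone, it is also open whether the step seen here would hold on another ring substitution pattern.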